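The source may hold more compounds than are shown below. What is called first, only, known or untested is meant among the compounds shown, and "the series" means these compounds.

Compound 1 `Cc1ccc(OCCCON2C(N)=NC(N)=NC23CCOCC3)cc1` gives > 90% in an assay on isolated protein for inhibition of Dihydrofolate reductase (Homo sapiens), read by spectrophotometry, using NADPH, with stated times of 5 s and 6 min, tested at 5 uM; on this read-out higher numbers stand for a stronger effect at the one concentration tested and lower numbers for a weaker effect; this is a limit of the assay, not a number.
Compound 2 `NC1=NC2(CCSCC2)N(OCCCOc2ccc(Br)cc2)C(N)=N1` gives > 90% in this assay; this too is a limit, not a number.
Compound 3 `COc1ccc(OCCCON2C(N)=NC(N)=NC23CCSCC3)cc1` gives 81.3% in this assay.

Compound 1 thus stands at the limit of > 90% in this assay, at which 2 of the 3 values shown sit, so only a floor is known for it and not how far above that floor it lies. Compound 4 `NC1=NC2(CCOCC2)N(OCCCOc2ccccc2)C(N)=N1` has not yet been measured. It differs from compound 1 as follows: hydrogen in place of methyl on an aromatic carbon. Going by the values given here, no measured step concerns this exact change. Among the compounds with values here, the one measured step, a number at least 8.7 percentage points lower from compound 2 to compound 3 (that floor lies within the scatter), exchanges a different group on an aromatic carbon and lands within the scatter, which gives little reason to expect a large move for a small exchange at that kind of position. With compound 1 already at a limit, a value near that limit or a little under it is the natural expectation for compound 4. The step of a number at least 3 percentage points lower from compound 1 to compound 4 (that floor lies within the scatter) that this estimate means is expected to be small. Compound 4 is therefore expected to give about 87% in this assay, with a range from 74% to 95%.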

Compound 4, a percentage reported as inhibition, at one concentration (the size of the read-out at that concentration, not a potency): > 90%
Compound 4: a limit, no number (the forecaster's own chance of this, stated with the estimate: 45%); middle value at least 3 percentage points away from the limit.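

Compound 1 and compound 4 both sit at the same limit of the assay rather than at a readable number, so no step can be read between them: the limit of > 90% in this assay, at which 3 of the 4 values shown sit.

The compounds shown leave open how far past that limit each one lies, and so whether hydrogen in place of methyl on the aromatic carbon changes the inhibition at all.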